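A Second Hydroxy Group on the Phenyl Ring

This account rests on a few compounds, and the source may have more. Where it says the series, first, only, none or still open, it means among the compounds named here.

Compound 1 `O=C(OCCCc1ccccc1)c1cc(-n2cc(-c3cccc(O)c3)nn2)ccc1O`: 9%
Compound 2 `COc1ccccc1-c1cn(-c2ccc(O)c(C(=O)Nc3cccc(C(F)(F)F)c3)c2)nn1`: 65%
Compound 3 `COc1ccc(-c2cn(-c3ccc(O)c(C(=O)O)c3)nn2)cc1`: 9%

All three compounds were tested in a functional assay on CCRF-CEM cells (Homo sapiens) for inhibition, read by MTT assay, with a stated time of 2 days, tested at 10 uM; on this read-out higher numbers stand for more inhibition at the one concentration tested (going by the name of the read-out) and lower numbers for less inhibition. Compound 1 gives 9% there, and compound 3 gives 9%; the two stand level within the scatter and together make up the low end of the group. Compound 2, with 65%, sits well beyond the scatter above both of them, so the number for compound 1 is among the lowest of the small set shown.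

Compound 4 `O=C(OCCCc1ccccc1)c1cc(-n2cc(-c3cc(O)ccc3O)nn2)ccc1O` is the next compound to be measured. It keeps the whole frame of compound 1 and changes a single position: hydroxy in place of hydrogen on an aromatic carbon. Among the measured compounds shown here, because compound 1 starts from 9%, and no other pair here shows what adding a hydroxy group does, the expected step from compound 1 to compound 4 is small, likely within the scatter, with at most a slight rise: a number 4 percentage points higher from compound 1 to compound 4 (within the scatter). Compound 4 is therefore estimated to give about 13%, with a range from 0% to 32%.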

Compound 4, a percentage reported as inhibition, at one concentration (the size of the read-out at that concentration, not a potency): 81%
The estimate for compound 4 lay 68 percentage points below the measured number; the whole stated range lies below it.
By their numbers in this assay, from the lowest: compounds 1 and 3 (each within the scatter of the next); then compound 2; then compound 4.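

In this assay the hydroxyphenyl ring proves highly sensitive to substitution at this position: the change from 3-hydroxyphenyl to 2,5-dihydroxyphenyl gives a number 72 percentage points higher from compound 1 to compound 4 (beyond the scatter) and adds only one heavy atom. The earlier compounds shown here could not show this, as no pair among them differed in a single place, and here a hydroxy group ortho to a large group and para to a hydroxy group is all that separates two otherwise identical compounds. No measurement here explains this rise.

On these data alone, it remains open whether the rise is specific to the hydroxy group, or whether an amine or a fluorine atom at the same position would also produce it. As far as these compounds go, it is also open whether the new hydroxy group would give such a rise without the one already on the ring.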